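The source may hold more compounds than are shown below. What is called first, only, known or untested is meant among the compounds shown, and "the series" means these compounds.

Measured so far, in a functional assay on HepG2 cells (Homo sapiens) for cytotoxicity, read by MTT assay, with a stated time of 72 h; on this read-out lower numbers stand for stronger inhibition and higher numbers for weaker inhibition:
compound 1 `COc1ccc2ccc(=O)oc2c1C(/C=C/c1ccc(C(F)(F)F)cc1)=N/NC(N)=O` gives 96 nM
compound 2 `COc1ccc2ccc(=O)oc2c1C1=NN(C(N)=O)C(c2cccs2)C1` gives 26 nM

Of these two numbers, compound 1 holds the higher one, and its gap to compound 2 lies beyond the usual scatter. Compound 3 `COc1ccc2ccc(=O)oc2c1C(/C=C/c1cccs1)=N/NC(N)=O` has not yet been measured. It differs from compound 1 in one place: thiophen-2-yl in place of 4-(trifluoromethyl)phenyl on a double-bonded chain carbon bound to a double-bonded chain carbon. Within the data shown here, compound 2 also carries a thiophen-2-yl group, though on a different framework, so no direct step shows how this exchange alone plays out. In this assay a modest step toward a lower number, or none beyond the scatter, is expected, amounting to a 1.4-fold lower number from compound 1 to compound 3 (0.14 log units; within the scatter). Compound 3 is therefore estimated at about 70 nM, within 25 nM to 200 nM.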

Compound 3, half-maximal inhibitory concentration: 75 nM
The estimate for compound 3 lay 1.1-fold (0.03 log units) below the measured number; low and high end bracket the measured number.
By their numbers in this assay, from the lowest: compound 2; then compounds 3 and 1 (each within the scatter of the next).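

In this assay, exchanging the 4-(trifluoromethyl)phenyl group for a thiophen-2-yl group gives a 1.3-fold lower number from compound 1 to compound 3 (0.11 log units; within the scatter) and so leaves the read-out essentially unchanged. This position therefore accepts a five-membered aromatic ring with a sulfur atom as readily as a larger six-membered carbon ring bearing fluorine atoms. No supporting data explain this result. On these data alone, whether the same holds for a plain phenyl, a furan-2-yl or a cyclohexyl group at this place stays open.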